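The source may hold more compounds than are shown below. What is called first, only, known or untested is meant among the compounds shown, and "the series" means these compounds.

The measured compounds are compound 1 `CCCOc1ccc(C2(c3ccc(O)cc3)C(=O)Nc3c2ccc(F)c3F)cc1`, compound 2 `CCCCCOc1ccc(C2(c3ccc(O)cc3)C(=O)Nc3c2ccc(F)c3F)cc1` and compound 3 `CCCC1(c2ccc(O)cc2)C(=O)Nc2c1ccc(F)c2F`. In a functional assay on MCF7 cells (Homo sapiens) for cytotoxicity, read by WST assay, with a stated time of 72 h (a higher number here means a weaker inhibitor, a lower number a stronger inhibitor), compound 1 gives 356 nM. For compound 2 this assay reports only a limit, > 1000 nM. For compound 3 this assay likewise reports only a limit, > 1000 nM. Compound 4 `CCCCCC1(c2ccc(O)cc2)C(=O)Nc2c1ccc(F)c2F` has not yet been measured.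

From compound 1 to compound 2 the change is ethyl in place of hydrogen on a saturated chain carbon, three bonds along the chain from an oxygen on an aromatic ring, and it produces an at least 2.8-fold higher number from compound 1 to compound 2 (0.44 log units; beyond the scatter). Compound 4 differs from compound 3 by ethyl in place of hydrogen on a saturated chain carbon, three bonds along the chain from a saturated ring carbon. This is the same kind of change, but not the same one, since the place differs: in the first it sits three bonds along the chain from an oxygen on an aromatic ring, in the second three bonds along the chain from a saturated ring carbon. The difference between the core of compound 1 and the core of compound 3 is not broken down here.

Two of the three values already sit at the limit of > 1000 nM in this assay, at which 2 of the 3 values shown sit, and compound 3 is one of them, so a number for compound 4 would need the chain lengthening to strengthen inhibition, whereas the measured step weakened it. Compound 4 is therefore expected to give a step that the limit leaves unreadable from compound 3 to compound 4, most likely again only a limit. Compound 4 is estimated at 3000 nM, between 1000 nM and 10000 nM.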

Compound 4, half-maximal inhibitory concentration: 96 nM
Compound 4: middle estimate off by 31-fold (1.49 log units), on the high side, and the stated range ends above it.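

In this assay, the change from propyl to pentyl, three bonds along the chain from a saturated ring carbon, gives an at least 10-fold lower number from compound 3 to compound 4 (1.01 log units; beyond the scatter). The same kind of lengthening therefore did not carry over from one core to the other with its direction intact: the same change on two cores in this assay, an at least 2.8-fold higher number (0.44 log units; beyond the scatter) from compound 1 to compound 2 and an at least 10-fold lower number (1.01 log units; beyond the scatter) from compound 3 to compound 4, at least 29-fold (1.46 log units) apart, beyond the scatter of two such steps Both steps rest on a limit and give only a bound rather than an exact size, and a single pair on each core does not show whether the core or the place of the change decides the outcome, nor does it give a rule for any further core.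

The compounds shown leave open how a butyl or a hexyl chain would behave on either core, and therefore whether pentyl is a special case among chain lengths. They also leave open whether a chain ending in an amine or a carboxylic acid, in place of pentyl, would hold the value of compound 4, 96 nM.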